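The source may hold more compounds than are shown below. What is called first, only, known or untested is meant among the compounds shown, and "the series" means these compounds.

Compounds measured so far in a functional assay on HepG2 cells (Homo sapiens) for inhibition, read by MTT assay, with a stated time of 72 h; a lower number here means a stronger inhibitor, a higher number a weaker inhibitor:

Compound 1, `COc1cccc(-n2cc(COc3cccc(NC(=O)Nc4ccc(Cl)c(C(F)(F)F)c4)c3)nn2)c1`: 1310 nM
Compound 2, `Cc1ccc(-n2cc(COc3cccc(NC(=O)Nc4ccc(Cl)c(C(F)(F)F)c4)c3)nn2)cc1`: 5430 nM
Compound 3, `O=C(Nc1cccc(OCc2cn(-c3cccc(Br)c3)nn2)c1)Nc1ccc(Cl)c(C(F)(F)F)c1`: 1040 nM

Compound 3 gives the lowest number of the three in this assay. Its nearest neighbour is compound 1, and the difference between them, a 1.3-fold lower number from compound 1 to compound 3 (0.10 log units; within the scatter), sits within the usual scatter, so the two cannot be told apart. The furthest is compound 2, and the change a 5.2-fold lower number from compound 2 to compound 3 (0.72 log units; beyond the scatter) lies beyond the scatter.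

Compound 4, `O=C(Nc1cccc(OCc2cn(-c3cccc(I)c3)nn2)c1)Nc1ccc(Cl)c(C(F)(F)F)c1`, has not yet been measured. Compared with compound 3 the difference is iodo in place of bromo on an aromatic carbon, that is, one halogen replaced by the next heavier one on the same aromatic carbon, meta to a large group. Among the compounds with values here, none of the measured steps swaps bromo for iodo. The closest guide is the step from a methoxy to a bromo at this carbon, a 1.3-fold lower number from compound 1 to compound 3 (0.10 log units; within the scatter), which stayed within the scatter, whereas moving the group to another position, as in a 4.1-fold higher number from compound 1 to compound 2 (0.62 log units; beyond the scatter), mattered more. A small change, if any, is therefore expected, and the estimated step of a 1.2-fold lower number from compound 3 to compound 4 (0.06 log units; within the scatter) should stay within the scatter. Compound 4 is estimated at 900 nM in this assay, with a range of 350 nM to 2500 nM.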

Compound 4, half-maximal inhibitory concentration: 4780 nM
Beside the measured number, compound 4's estimate is 5.3-fold (0.73 log units) below it; measured number above the stated range.
By their numbers in this assay, from the lowest: compounds 3 and 1 (each within the scatter of the next); then compounds 4 and 2 (each within the scatter of the next).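

In this assay this carbon turns out not to treat all halogens alike: going from bromo to the next heavier halogen, iodo, is a real change (a 4.6-fold higher number from compound 3 to compound 4 (0.66 log units; beyond the scatter)), even though methoxy and bromo could not be told apart here (a 1.3-fold lower number from compound 1 to compound 3 (0.10 log units; within the scatter)). Iodo also separates from methoxy at the same carbon (a 3.6-fold higher number from compound 1 to compound 4 (0.56 log units; beyond the scatter)), while the 3-iodophenyl and 4-methylphenyl groups cannot be told apart (a 1.1-fold lower number from compound 2 to compound 4 (0.06 log units; within the scatter)). Nothing available explains why iodo and bromo part ways at this carbon.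

Open, going by these compounds, is whether fluoro, an amine or a carboxylic acid on this carbon would group with bromo and methoxy or with iodo. Also open, on these data alone, is whether the gap between bromo and iodo would persist in any test other than this one on HepG2 cells.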